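Thiophen-2-yl for phenyl on the ketone of compound 2

The source may hold more compounds than are shown below. What is called first, only, known or untested is meant among the compounds shown, and "the series" means these compounds.

Measured compounds in a functional assay on MT4 cells (Homo sapiens) for antiproliferative activity, read by MTT assay, with a stated time of 96 h; a lower number here means that less compound is needed, a higher number that more compound is needed for the effect:
compound 1 `CS(=O)(=O)/C(C#N)=C/c1c[nH]c2ccccc12`: > 100000 nM
compound 2 `N#C/C(=C\c1c(-c2ccccc2)[nH]c2ccccc12)C(=O)c1ccccc1`: 500 nM
compound 3 `CCOC(=O)/C(=C/c1c(-c2ccccc2)[nH]c2ccccc12)C(=O)c1ccccc1`: 7000 nM

Compound 2 gives 500 nM in this assay, the lowest number among the two compounds that give a number. Compound 3 gives 7000 nM, and the gap from compound 2 lies beyond the scatter of repeated measurements. For compound 1 the assay reports only a limit, > 100000 nM, not a number. This is the limit of > 100000 nM in this assay, at which 1 of the 3 values shown sits.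

Compound 4 `N#C/C(=C\c1c(-c2ccccc2)[nH]c2ccccc12)C(=O)c1cccs1` is not yet measured. It differs from compound 2 in one place: thiophen-2-yl in place of phenyl on a carbonyl carbon. Among the measured compounds shown here, no step between two measured compounds shows this change, so nothing measured here tells how it will read. The expectation is a step within the scatter, in no set direction, with the number of compound 4 close to the number of compound 2. Compound 4 is therefore estimated at 600 nM in this assay, with a range from 200 nM to 2000 nM. This estimate means a step of a 1.2-fold higher number from compound 2 to compound 4 (0.08 log units; within the scatter), which is expected to stay inside the usual scatter.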

Compound 4, half-maximal effective concentration: 400 nM
Estimate against measurement, compound 4: 1.5-fold (0.18 log units) above; the measured number falls inside the stated range.
By their numbers in this assay, from the lowest: compounds 4 and 2 (each within the scatter of the next); then compound 3. At a limit, above all of these: compound 1.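

Replacing phenyl with thiophen-2-yl on the carbonyl carbon gives a 1.3-fold lower number from compound 2 to compound 4 (0.10 log units; within the scatter) in this assay, so this ring swap, which brings a five-membered aromatic ring with one hetero atom and one hydrogen-bond acceptor, leaves the reading where it was. The earlier compounds shown here gave no view of this position, as compound 2 and compound 3 both carry the benzoyl group and differ only at the nitrile, where compound 3 has an ethyl ester and gives 7000 nM; the ketone's aromatic ring can therefore change here without a step beyond the scatter, at least for this one pair on the nitrile series. Nothing measured bears on why the two rings read alike.

Still open, on these data alone, is whether the position accepts anything other than an aromatic ring, for example a cyclohexyl group, a short alkyl chain or a chain ending in an amine. Among the compounds shown here, also open is whether thiophen-2-yl reads the same way on the ethyl ester of compound 3, since the only step at this carbonyl comes from the nitrile pair.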